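Bicyclic alkyl in place of pyridinyl on the amide

The source may report more compounds than this note shows. Statements on the series, on what has been measured and on what is new or still open speak of the compounds shown alone.

Three compounds share one core and were all measured in an ADME assay on MRC5 cells (Homo sapiens) for inhibition, with a stated time of 72 h; a lower number here means that less compound is needed, a higher number that more compound is needed for the effect. Compound 1 `COc1cccc(OC)c1C(=O)Nc1c[nH]nc1C(=O)N[C@H]1CC[C@H](OC)CC1` carries a 4-methoxycyclohexyl group on an amide-type nitrogen, and in this assay compound 1 gives 31000 nM. Compound 2 `COc1cccc(OC)c1C(=O)Nc1c[nH]nc1C(=O)NCCCOC(C)C` has 3-isopropoxypropyl in that place; in this assay compound 2 reaches only > 50000 nM, which is a limit of the assay and not a number. Compound 3 `COc1cccc(OC)c1C(=O)Nc1c[nH]nc1C(=O)Nc1ccccn1` bears pyridin-2-yl there; in this assay compound 3 likewise sits at the limit > 50000 nM. Compound 3 thus stands at the top of what this assay can report, a position it shares with one other compound (the limit of > 50000 nM in this assay, at which 2 of the 3 values shown sit).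

Compound 4 `COc1cccc(OC)c1C(=O)Nc1c[nH]nc1C(=O)NC1CC2CCC1C2` differs from compound 3 in one place: a group of 7 heavy atoms (7 carbon; 2 five-membered non-aromatic rings of carbon only) in place of a group of 6 heavy atoms (5 carbon, 1 nitrogen; one six-membered aromatic ring with 1 hetero atom), on an amide-type nitrogen. The measured steps that touch compound 3 are an at least 1.6-fold higher number from compound 1 to compound 3 (0.20 log units; that floor lies within the scatter) and a step that the two limits leave unreadable from compound 2 to compound 3. Within the data shown here, neither gives a direction or a size that the scatter would not cover, and the one numbered value among the three, that of compound 1, lies close to the limit itself. In this assay compound 4 is therefore expected near the limit, estimated at 40000 nM within 15000 nM to 100000 nM, which amounts to an expected step of an at least 1.2-fold lower number from compound 3 to compound 4 (0.09 log units; that floor lies within the scatter).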

Compound 4, half-maximal effective concentration: > 50000 nM
Compound 4 was reported as a limit (the forecaster's own chance of this, stated with the estimate: 50%); middle value at least 1.2-fold (0.09 log units) away from the limit.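

In this assay compound 4 gives > 50000 nM as a limit of the assay and not a number, so a group of carbon only with two five-membered non-aromatic rings leaves the compound at that limit. Among these compounds, the one step that can be read is an at least 1.6-fold higher number from compound 1 to compound 4 (0.20 log units; that floor lies within the scatter) and gives only a floor, while the steps among compounds at the limit cannot be read. The bicyclic carbon group, pyridin-2-yl and 3-isopropoxypropyl on the amide-type nitrogen now all end in the same place, with compound 1 alone going against this pattern: the limit of > 50000 nM in this assay, at which 3 of the 4 values shown sit.

No order among compound 2, compound 3 and compound 4 can be drawn, since none of them has a number. Compound 1 at 31000 nM leaves open whether a 4-aminocyclohexyl group or a 4-carboxycyclohexyl group in that place would give a clearly lower number.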